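Nitrogen substituent swap: compound 3 to compound 4

The source may report more compounds than this note shows. Statements on the series, on what has been measured and on what is new or still open speak of the compounds shown alone.

In a functional assay on K562 cells (Homo sapiens) for cytotoxicity, read by trypan blue exclusion, with a stated time of 96 h (on this read-out lower numbers stand for stronger inhibition and higher numbers for weaker inhibition), compound 1 (`COC(=O)CNc1cc(CS(=O)(=O)/C=C/c2c(OC)cc(OC)cc2OC)ccc1OC`) gives 100 nM while compound 2 (`COC(=O)[C@H](C)Nc1cc(CS(=O)(=O)/C=C/c2c(OC)cc(OC)cc2OC)ccc1OC`) gives 200 nM and compound 3 (`COC(=O)C(Nc1cc(CS(=O)(=O)/C=C/c2c(OC)cc(OC)cc2OC)ccc1OC)c1ccc(Cl)cc1`) gives 200 nM as its reading, level with compound 2 and within the scatter of compound 1. Compound 4 (`COc1cc(OC)c(/C=C/S(=O)(=O)Cc2ccc(OC)c(NC(F)(F)C(=O)O)c2)c(OC)c1`) carries carboxy(difluoro)methyl in place of (4-chlorophenyl)(methoxycarbonyl)methyl on a nitrogen on an aromatic ring. The steps (a 2.0-fold higher number from compound 1 to compound 2 (0.30 log units; within the scatter)) and (a 2.0-fold higher number from compound 1 to compound 3 (0.30 log units; within the scatter)) and (no change at the digits printed from compound 2 to compound 3 (within the scatter)) altered the same nitrogen substituent, and all stayed within the scatter. Going by the values given here, no measured compound carries carboxy(difluoro)methyl, so this read-across is weak. In this assay the expected step is none beyond the scatter (a 1.3-fold lower number from compound 3 to compound 4 (0.12 log units; within the scatter)). Compound 4 is estimated at 150 nM (range 40 nM to 600 nM).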

Compound 4, half-maximal inhibitory concentration: 150 nM
The estimate for compound 4 equals the measured number at the digits printed; low and high end bracket the measured number.
By their numbers in this assay, from the lowest: compounds 1, 4, 2 and 3 (each within the scatter of the next).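

In this assay carboxy(difluoro)methyl on the nitrogen on an aromatic ring gives a 1.3-fold lower number from compound 3 to compound 4 (0.12 log units; within the scatter) and a 1.3-fold lower number from compound 2 to compound 4 (0.12 log units; within the scatter) and a 1.5-fold higher number from compound 1 to compound 4 (0.18 log units; within the scatter) as its steps, all within the scatter. This substituent has no ring and no methoxycarbonyl group, so neither the 4-chlorophenyl ring of compound 3 nor the methoxycarbonyl group of compound 1, compound 2 and compound 3 is required for a reading in this range. On these data alone, whether the non-fluorinated carboxymethyl group, a primary amide or a longer chain on this nitrogen would read alike stays open. No measurement at hand explains why these substituents read alike.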